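Aryl swap on the piperazine nitrogen of the shared core

The compounds below may be only part of what the source reports. "The series", "measured", "known", "first", "only" and "open" are said of these compounds alone.

Compound 1 `S=c1oc(-c2ccc3c(c2)OCCO3)nn1CN1CCN(c2cccc(Cl)c2Cl)CC1` sits at the limit > 50000 nM in a functional assay on HeLa cells (Homo sapiens) for antiproliferative activity, read by MTT assay, with a stated time of 48 h; a lower number here means a stronger inhibitor, a higher number a weaker inhibitor. Among the measured compounds shown here, compound 2 `COc1cccc(N2CCN(Cn3nc(-c4ccc5c(c4)OCCO5)oc3=S)CC2)c1` gives 18000 nM, the only full number in this assay. The step of an at least 2.7-fold lower number from compound 1 to compound 2 (0.44 log units; beyond the scatter) was the gain that brought it there, and the limit of > 50000 nM in this assay, at which 1 of the 2 values shown sits, marks the limit at which compound 1 stands. Compound 3 `S=c1oc(-c2ccc3c(c2)OCCO3)nn1CN1CCN(c2ccccc2Cl)CC1` differs from compound 2 by 2-chlorophenyl in place of 3-methoxyphenyl on an amine nitrogen in a ring, moving partly back toward the chlorinated aryl of compound 1. An increase in the number is therefore expected, about a 2.2-fold higher number from compound 2 to compound 3 (0.35 log units; beyond the scatter), with a fair chance of only a limit. Compound 3 is estimated at 40000 nM, between 15000 nM and 120000 nM.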

Compound 3, half-maximal inhibitory concentration: 37400 nM
Compound 3: middle estimate off by 1.1-fold (0.03 log units), on the high side, within the range that was stated.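

On the amine nitrogen in the ring, a single chloro group on the phenyl also falls short of the 3-methoxyphenyl of compound 2 in this assay, with a 2.1-fold higher number from compound 2 to compound 3 (0.32 log units; beyond the scatter). Hydrogen in place of one chloro gives an at least 1.3-fold lower number from compound 1 to compound 3 (0.12 log units; that floor lies within the scatter), so this change shows no firm gain. Compound 1 stands at a limit, which makes that step only a floor: the limit of > 50000 nM in this assay, at which 1 of the 3 values shown sits.

Group identity and ring placement change together between compound 2 and compound 3, so their contributions stay unseparated. Open too, from the compounds shown here alone, is how an unsubstituted phenyl, or a phenyl carrying an amine, would read here.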